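The source may hold more compounds than are shown below. What is called first, only, known or untested is meant among the compounds shown, and "the series" means these compounds.

compound 1 `CC1CC/C(=N\Nc2ccc(Br)cc2)c2ncc(C(=O)O)c(=O)n21`: 2000 nM
compound 2 `COc1ccc(N/N=C2\CCC(C)n3c2ncc(C(=O)O)c3=O)cc1`: 128000 nM
compound 3 `Cc1ccc(N/N=C2\CCC(C)n3c2ncc(C(=O)O)c3=O)cc1`: 280 nM

All three values come from a functional assay (mast cells) for inhibition, with Rattus norvegicus as the target; a higher number here means that more compound is needed for the effect, a lower number that less compound is needed. Compound 3 has the lowest number of the three, so it needs the least compound for the effect.

The next compound, compound 4 `CC(=O)c1ccc(N/N=C2\CCC(C)n3c2ncc(C(=O)O)c3=O)cc1`, has not yet been measured. It keeps the shared core of compound 3 and has acetyl in place of methyl on an aromatic carbon, para to a large group (acetyl in place of methyl on an aromatic carbon).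

The measured steps all swap a group at this same place. Methyl in place of bromo gives a 7.1-fold lower number from compound 1 to compound 3 (0.85 log units; beyond the scatter), which is modest. Methoxy in place of bromo gives a 64-fold higher number from compound 1 to compound 2 (1.81 log units; beyond the scatter), and methyl in place of methoxy gives a 460-fold lower number from compound 2 to compound 3 (2.66 log units; beyond the scatter), both large. For the measured compounds named here, these steps show that the group here can matter greatly, but none of the measured compounds carries acetyl, so they offer no direct guide to its effect.

Bromo in compound 1 at 2000 nM and methoxy in compound 2 at 128000 nM both sit higher than methyl, so a rise is the more likely direction. The expected change is an 11-fold higher number from compound 3 to compound 4 (1.03 log units; beyond the scatter), a sizeable step with much uncertainty. The estimate for compound 4 is 3000 nM, with an expected range of 300 nM to 50000 nM.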

Compound 4, half-maximal effective concentration: 8100 nM
Estimate against measurement, compound 4: 2.7-fold (0.43 log units) below; the range from low to high includes it.
By their numbers in this assay, from the lowest: compound 3; then compound 1; then compound 4; then compound 2.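

Replacing the methyl group with acetyl comes at a high cost in this assay, with a 29-fold higher number from compound 3 to compound 4 (1.46 log units; beyond the scatter), so compound 3 remains the compound that needs the least for the effect. Acetyl also falls between the other two groups, with a 4.1-fold higher number from compound 1 to compound 4 (0.61 log units; beyond the scatter) and a 16-fold lower number from compound 2 to compound 4 (1.20 log units; beyond the scatter); the two groups containing oxygen, acetyl and methoxy, therefore differ widely at this place, and the presence of oxygen alone does not fix the number. Nothing available here explains why these groups differ, so the four compounds give a ranking but no reason for it.

As far as these compounds go, four groups at one place are too few to support a general rule, and it remains open whether an ethyl group, a chloro group or an amine would fall nearer to methyl or to methoxy. From the compounds shown here alone, it is also open whether the same order of groups would hold if the carboxylic acid on the shared core were replaced by an ester.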